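The source may report more compounds than this note shows. Statements on the series, on what has been measured and on what is new or still open speak of the compounds shown alone.

Compound 1 `COC(=O)c1ccc(NCc2cncn2Cc2ccccc2C(C)(C)C)cc1-c1ccccc1`: in a toxicity assay on NIH3T3 cells (Mus musculus) for cytotoxicity, read by resazurin assay (a higher number here means that more compound is needed for the effect, a lower number that less compound is needed), compound 1 gives "not determined" (no result reported).
Compound 2 `COC(=O)c1ccc(NCc2cncn2Cc2cccc(Br)c2)cc1-c1ccccc1`: in this assay compound 2 gives > 10000 nM, which is a limit of the assay and not a number.
Compound 3 `COC(=O)c1ccc(NCc2cncn2Cc2cccc(-c3ccccc3)c2)cc1-c1ccccc1`: in this assay compound 3 gives "not determined" (no result reported).

For the measured compounds named here, compound 3 therefore has no number of its own to stand on; among the three entries only one value appears, and that one sits at the limit of > 10000 nM in this assay, at which 1 of the 3 values shown sits. The step to compound 4 `COC(=O)c1ccc(NCc2cncn2Cc2cccc(N)c2)cc1-c1ccccc1` is a small one in the structure: amino in place of phenyl on an aromatic carbon. Going by the values given here, no measured step of this kind is available to lean on, so no direction beyond the scatter can be claimed for this assay; the one value shown suggests the readout may again end at a limit. For compound 4 the estimated value in this assay is 20000 nM, expected to lie between 5000 nM and 80000 nM.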

Compound 4, half-maximal effective concentration: > 10000 nM
Compound 4: no number, only a limit; the forecaster's own chance of this, stated with the estimate: 75%; the middle value lies beyond the limit too.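

In this assay, for the compounds shown here, compound 2 and compound 4 each end at a limit of the assay rather than a number, so no step between them can be read. The compounds shown leave open what concentration produces the effect.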